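The source may hold more compounds than are shown below. What is called first, only, known or untested is meant among the compounds shown, and "the series" means these compounds.

Values in a functional assay on HL-60 cells (Homo sapiens) for inhibition, read by sulforhodamine B assay, with a stated time of 48 h, tested at 10 uM (a higher number here means more inhibition at the concentration tested (going by the name of the read-out), a lower number less inhibition), for the three measured compounds:

compound 1 `Brc1cn2ccnc2c(-c2ccc3ncn(C4CCCCC4)c3c2)n1` — 18%
compound 2 `O=Cc1ccc(-c2cn3ccnc3c(-c3ccc4ncn(C5CCCCC5)c4c3)n2)cc1` — 16.5%
compound 3 `COc1ccccc1-c1cn2ccnc2c(-c2ccc3ncn(C4CCCCC4)c3c2)n1` — 14.6%

Compound 2 stands second highest of the three. Its nearest neighbour is compound 1, and the step of a number 1.5 percentage points lower from compound 1 to compound 2 (within the scatter) lies within the scatter; its furthest is compound 3, and the step of a number 1.9 percentage points lower from compound 2 to compound 3 (within the scatter) also lies within the scatter. All three compounds share the same core and differ only in the group on one aromatic carbon, and none of them is separated from another by more than the usual scatter.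

Compound 4 `FC(F)(F)c1cccc(-c2cn3ccnc3c(-c3ccc4ncn(C5CCCCC5)c4c3)n2)c1` is not yet measured. The change from compound 2 is 3-(trifluoromethyl)phenyl in place of 4-formylphenyl on an aromatic carbon. Among the compounds with values here, the steps that bear on it are those exchanging the group on that same aromatic carbon: a number 1.5 percentage points lower from compound 1 to compound 2 (within the scatter), a number 3.4 percentage points lower from compound 1 to compound 3 (within the scatter) and a number 1.9 percentage points lower from compound 2 to compound 3 (within the scatter), each within the scatter. Three different groups at this position, including bromo, 4-formylphenyl and 2-methoxyphenyl, have given values in a narrow band, so no step beyond the scatter is expected in this assay in either direction for a further aryl group here.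

Compound 4 is therefore expected to give about 16%, in a range from 6% to 28%. The step of a number 0.5 percentage points lower from compound 2 to compound 4 (within the scatter) is the expected outcome, within the scatter.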

Compound 4, a percentage reported as inhibition, at one concentration (the size of the read-out at that concentration, not a potency): 1.06%
For compound 4 the middle estimate is 14.9 percentage points above the measured one; the whole stated range lies above it.
By their numbers in this assay, from the lowest: compound 4; then compounds 3, 2 and 1 (each within the scatter of the next).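

Working from this assay, the group on this aromatic carbon is not without consequence: 3-(trifluoromethyl)phenyl separates compound 4 from all three earlier compounds by more than the scatter (a number 15.4 percentage points lower from compound 2 to compound 4 (beyond the scatter); a number 13.5 percentage points lower from compound 3 to compound 4 (beyond the scatter); a number 16.9 percentage points lower from compound 1 to compound 4 (beyond the scatter)). Compound 2 and compound 3 also carry a substituted phenyl group here and remain within the scatter of compound 1, so the step goes with this particular group and not with a phenyl group at this position as such. The data shown give no reason for this step.

From the compounds shown here alone, whether the step belongs to the trifluoromethyl group itself or to the combination of that group with its place on the phenyl ring remains open, as does the outcome with a non-aryl group on this carbon, such as an amine or a carboxylic acid. All four values come from a single concentration in one cell line, so potency across the series and the behaviour of these compounds in other cells also remain open.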